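A few compounds are considered here, and "the series" means these few. Any claim that something is new, unique, unknown or untested is made for them only; others in the source may bear on it.

Of the compounds shown here, two have been measured. In an ADME assay on microsomes from liver (Homo sapiens) for metabolic stability, with a stated time of 30 min, tested at 1 uM (a higher number here means that the compound lasts longer, a lower number that the compound disappears faster), compound 1 `COc1ccc2[nH]c(C(=O)N3CC(=O)N(Cc4ccccc4)[C@@H](CCc4ccccc4)C3)cc2c1` gives 0.167 h. Compound 2 `COc1ccc2[nH]c(C(=O)N3CC(=O)N(Cc4ccccc4)[C@@H](COC(C)(C)C)C3)cc2c1` gives 0.278 h in this assay. Compound 2 is the point of departure here; its number and that of compound 1 are separated only by a 1.7-fold higher number from compound 1 to compound 2 (0.22 log units; within the scatter), so the two cannot be told apart on these data. Compound 3 `COc1ccc2[nH]c(C(=O)N3CC(=O)N(Cc4ccccc4)[C@@H](N4CCc5ccccc54)C3)cc2c1` has not yet been measured. It differs from compound 2 in one place: 2,3-dihydro-1H-indol-1-yl in place of (tert-butoxy)methyl on a saturated ring carbon. Going by the values given here, the only measured step bears on this change loosely, as it exchanged a different pair of groups at the same position and stayed within the scatter; it gives no reason to expect a large move in either direction. No step beyond the scatter is therefore expected in this assay. The expected step is a 1.3-fold lower number from compound 2 to compound 3 (0.10 log units; within the scatter). Compound 3 is thus estimated to give about 0.22 h, between 0.08 h and 0.6 h.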

Compound 3, half-life: 0.25 h
Compound 3: middle estimate off by 1.1-fold (0.06 log units), on the low side, within the range that was stated.
By their numbers in this assay, from the lowest: compounds 1, 3 and 2 (each within the scatter of the next).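

In this assay, placing 2,3-dihydro-1H-indol-1-yl on the saturated ring carbon instead of (tert-butoxy)methyl gives a 1.1-fold lower number from compound 2 to compound 3 (0.05 log units; within the scatter), and placing it there instead of phenethyl gives a 1.5-fold higher number from compound 1 to compound 3 (0.18 log units; within the scatter). Going by these compounds alone, the earlier compounds showed only that two groups attached through a chain could not be told apart here; now a group with two rings, one of them aromatic, attached through its ring nitrogen also cannot be told apart from either. The data at hand offer no explanation for this flat picture.

On these data alone, whether a small amine or a carboxylic acid at this position would produce a step beyond the scatter remains open. So does whether any change to the benzyl group would do so.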